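Bromo on the Anilino Ring of Compound 1

A few compounds are considered here, and "the series" means these few. Any claim that something is new, unique, unknown or untested is made for them only; others in the source may bear on it.

Working notes on the series. Among the measured compounds shown here, compound 1 `C=CC(=O)Nc1cccc(NC(=O)CSc2nc(Nc3ccccc3)c3ccccc3n2)c1` gives 7310 nM in a functional assay on MGC-803 cells (Homo sapiens) for inhibition, read by MTT assay, with a stated time of 72 h (on this read-out higher numbers stand for weaker inhibition and lower numbers for stronger inhibition), the lowest of the two numbers measured so far. Its nearest neighbour is compound 2 `O=C(CSc1nc(Nc2ccccc2)c2ccccc2n1)Nc1ccc(Cl)cc1Cl`, which gives 12300 nM in this assay; the step of a 1.7-fold higher number from compound 1 to compound 2 (0.23 log units; within the scatter) puts 2,4-dichlorophenyl in place of 3-((vinylcarbonyl)amino)phenyl on an amide-type nitrogen and stays within the scatter.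

Compound 3 `C=CC(=O)Nc1cccc(NC(=O)CSc2nc(Nc3ccccc3Br)c3ccccc3n2)c1` is not yet measured. It differs from compound 1 by bromo in place of hydrogen on an aromatic carbon, on an aromatic carbon of a six-membered aromatic ring of carbon only, ortho to a large group; cut one bond further out, anilino becomes (2-bromophenyl)amino. For the measured compounds named here, no measured step touches this part of the shared core: the only step available changes the group on the amide-type nitrogen, and it stayed within the scatter. There is thus no basis for expecting a shift beyond the scatter in this assay in either direction. Compound 3 is expected to give 7500 nM in this assay, within 3000 nM to 19000 nM. The step of a 1.0-fold higher number from compound 1 to compound 3 (0.01 log units; within the scatter) is estimated to remain within the scatter.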

Compound 3, half-maximal inhibitory concentration: 12800 nM
For compound 3 the middle estimate is 1.7-fold (0.23 log units) below the measured one; measured number inside the range.
By their numbers in this assay, from the lowest: compounds 1, 2 and 3 (each within the scatter of the next).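

In this assay, among the compounds shown here, bromo in place of hydrogen, on an aromatic carbon ortho to a large group, gives the first reading on the anilino part of the shared core: a 1.8-fold higher number from compound 1 to compound 3 (0.24 log units; within the scatter). The earlier step changed only the group on the amide-type nitrogen, so this result adds that (2-bromophenyl)amino in place of anilino, a change of one bromine atom, also produces no shift that can be told from the scatter. No measurement at hand accounts for this reading.

Going by these compounds, it remains open whether a carboxylic acid, an amine or a methoxy group in the same place would move the number beyond the scatter. Also open, on these data alone, is whether (2-bromophenyl)amino would read the same with 2,4-dichlorophenyl on the amide-type nitrogen.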